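Flipping one ring stereocentre in a naphthyl methylene-lactone

A few compounds are considered here, and "the series" means these few. Any claim that something is new, unique, unknown or untested is made for them only; others in the source may bear on it.

Measured compounds:
Compound 1, `C=C1C(=O)O[C@H](c2ccc3ccccc3c2)[C@H]1C`, in a functional assay on MIA PaCa-2 cells (Homo sapiens) for cytotoxicity, read by MTT assay, with a stated time of 72 h, tested at 1 uM (on this read-out lower numbers stand for a stronger effect and higher numbers for a weaker effect at the one concentration tested), gives 74%.
Compound 2, `C=C1C(=O)O[C@@H](c2ccc3ccccc3c2)[C@H]1c1ccccc1`, in this assay gives 125%.

Compound 2 stands highest of the two numbers recorded in this assay; its nearest neighbour is compound 1, whose number is lower by a gap that lies beyond the scatter. The two compounds differ in more than one place, so nothing is drawn from that gap beyond what the two values show.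

Compound 3, `C=C1C(=O)O[C@H](c2ccc3ccccc3c2)[C@H]1c1ccccc1`, has not yet been measured in this assay. It differs from compound 2 as follows: the two compounds have the same atoms and bonds and differ only in configuration as drawn: 1 of 2 stereo elements differ; a stereocentre at a saturated ring carbon is drawn R in compound 2 and S in compound 3. Among the compounds with values here, no step of this kind between measured compounds is recorded, so the size and direction of the change in this assay are open; a change in either direction, or none beyond the scatter, is possible. Compound 3 is therefore expected to give about 105%, within 65% to 135%. The expected step is a number 20 percentage points lower from compound 2 to compound 3 (beyond the scatter).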

Compound 3, a percentage reported as activity, at one concentration (the size of the read-out at that concentration, not a potency): 29%
Beside the measured number, compound 3's estimate is 76 percentage points above it; the whole stated range lies above it.
By their numbers in this assay, from the lowest: compound 3; then compound 1; then compound 2.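

In this assay, the configuration at one saturated ring carbon proves enough on its own to produce a large change, with a number 96 percentage points lower from compound 2 to compound 3 (beyond the scatter). That step can be assigned to this stereocentre alone because nothing else in the structure changes: the fact that compounds 2 and 3 differ only in the configuration as drawn. With the configuration drawn in compound 3, phenyl in place of methyl on a saturated ring carbon also goes with a stronger effect, with a number 45 percentage points lower from compound 1 to compound 3 (beyond the scatter).

The compounds shown leave open whether compound 1 would respond in the same way to the same flip of configuration, and whether the stereocentre bearing the naphthyl group matters as much. They also leave open how an amine, a carboxylic acid or a longer chain in place of phenyl on this carbon would read at this single concentration.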